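From 2-chlorophenyl to 4-bromophenyl on a shared core

The source may hold more compounds than are shown below. What is called first, only, known or untested is meant among the compounds shown, and "the series" means these compounds.

Measured so far in a functional assay on MCF7 cells (Homo sapiens) for antiproliferative activity, read by MTT assay, with a stated time of 72 h; a higher number here means a weaker inhibitor, a lower number a stronger inhibitor
Compound 1 (`CCCSc1nc(N/N=C/c2ccccc2Cl)c2nnn(Cc3ccccc3)c2n1`) gives 13800 nM as a number
Compound 2 (`CCCSc1nc(N/N=C(\C)c2ccccc2O)c2nnn(Cc3ccc(F)cc3)c2n1`) gives > 64000 nM as a limit

Within the data shown here, compound 1 holds the only true number in this small set, with 13800 nM in this assay as its result. Compound 2 reads > 64000 nM and that entry is a limit of the assay, not a number.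

Compound 3 (`CCCSc1nc(N/N=C/c2ccc(Br)cc2)c2nnn(Cc3ccccc3)c2n1`) has not yet been measured. It keeps the core of compound 1 and changes in one place, on a carbon with a double bond to nitrogen, where 4-bromophenyl stands in place of 2-chlorophenyl (4-bromophenyl in place of 2-chlorophenyl on a carbon with a double bond to nitrogen). Among the measured compounds shown here, no measured pair here differs in a single place, so this change has no direct gauge. No shift beyond the usual scatter is therefore expected, and no firm direction either. The expected step (a 1.1-fold higher number from compound 1 to compound 3 (0.04 log units; within the scatter)) stays within that scatter. This expectation rests on compound 1 and its 13800 nM as the sole numerical anchor. Compound 3 is estimated at 15000 nM in this assay with an expected range from 5000 nM to 50000 nM as its bounds.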

Compound 3, half-maximal inhibitory concentration: > 64000 nM
Compound 3 ended at the assay's limit (the forecaster's own chance of this, stated with the estimate: 12%); middle value at least 4.2-fold (0.63 log units) away from the limit.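

Among these compounds, replacing 2-chlorophenyl with 4-bromophenyl on a carbon with a double bond to nitrogen gives the first single-place comparison in this set, and in this assay it amounts to an at least 4.6-fold higher number from compound 1 to compound 3 (0.66 log units; beyond the scatter). The entry for compound 3, > 64000 nM, is a limit of the assay and not a number. The comparison therefore shows that this position is sensitive to the exchange, with compound 1 still the only compound holding a true number, but it fixes only the direction of the step and a lower bound on its size, as the values now gather at one limit: the limit of > 64000 nM in this assay, at which 2 of the 3 values shown sit.

The exchange alters both the halogen and the place given in the group's name, so the compounds shown cannot tell whether chlorine giving way to bromine or the move from 2 to 4 accounts for the step, a question that 4-chlorophenyl or 2-bromophenyl would address. They also leave open how a phenyl ring carrying an amine or a carboxylic acid would behave on this carbon.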